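Biphenyl-lactone series: distal ring substitution

The source may hold more compounds than are shown below. What is called first, only, known or untested is meant among the compounds shown, and "the series" means these compounds.

Measured so far:
- compound 1, `O=C1C[C@H](O)C[C@@H](/C=C/c2c(Cl)cc(Cl)cc2-c2cc(Cl)cc(Cl)c2)O1`: 37 nM
- compound 2, `O=C1C[C@H](O)CC(CCc2ccccc2-c2ccccc2)O1`: 44000 nM

In an assay for inhibition of 3-hydroxy-3-methylglutaryl-coenzyme A reductase (Rattus norvegicus) (a higher number here means a weaker inhibitor, a lower number a stronger inhibitor), compound 1 gives 37 nM, the lower of the two numbers recorded. Within the data shown here, compound 2 gives 44000 nM in this assay, a gap far beyond the scatter; compound 2 differs from compound 1 in several places at once, so no single step between them can be read off.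

Compound 3, `Cc1ccccc1-c1cc(Cl)cc(Cl)c1/C=C/[C@@H]1C[C@@H](O)CC(=O)O1`, has not been measured in this assay. It differs from compound 1 by 2-methylphenyl in place of 3,5-dichlorophenyl on an aromatic carbon. Among the measured compounds shown here, no measured pair isolates this change, so the expectation rests on compound 1 alone. The step from compound 1 to compound 3 is expected to be a 4.1-fold higher number from compound 1 to compound 3 (0.61 log units; beyond the scatter), a moderate loss that is nonetheless beyond the scatter. Compound 3 is estimated at 150 nM in this assay, with a range from 40 nM to 600 nM.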

Compound 3, half-maximal inhibitory concentration: 370 nM
Compound 3: the middle estimate sits 2.5-fold (0.39 log units) below what was measured; measured number inside the range.
By their numbers in this assay, from the lowest: compound 1; then compound 3; then compound 2.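

In this assay, among these compounds, 2-methylphenyl in place of 3,5-dichlorophenyl gives a 10-fold higher number from compound 1 to compound 3 (1.00 log units; beyond the scatter), the first step that isolates a single place. This aromatic carbon, ortho to a large group and meta to two chloro groups, therefore responds to the identity of its aryl substituent, even though both groups hold one six-membered aromatic ring of carbon only and neither carries a hydrogen-bond donor or acceptor. Nothing on hand accounts for the size of this step.

Among the compounds shown here, the single swap cannot separate the loss of the two chlorines of the 3,5-dichlorophenyl from the arrival of the methyl group. As far as these compounds go, how an unsubstituted phenyl, or a phenyl bearing a methoxy group or an amine, would read at this position remains open.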